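This account rests on a few compounds, and the source may have more. Where it says the series, first, only, none or still open, it means among the compounds named here.

Compound 1 `COc1ccc2ncc(S(=O)(=O)c3cccc(C#N)c3)c(N3CCC(C)CC3)c2c1` belongs to a set of three close relatives that differ only in the group on one aromatic carbon of the shared core. In an assay on isolated protein for displacement of a labelled ligand from metabotropic glutamate receptor 5 (Homo sapiens), with a stated time of 60 min, tested at 1 uM (on this read-out lower numbers stand for less inhibition and higher numbers for more inhibition at the one concentration tested (going by the name of the read-out)), compound 1 gives 90%. Compound 2 `CC1CCN(c2c(S(=O)(=O)c3cccc(C#N)c3)cnc3ccc(Cl)cc23)CC1` gives 90% in this assay, and compound 3 `CC1CCN(c2c(S(=O)(=O)c3cccc(C#N)c3)cnc3ccc(F)cc23)CC1` gives 93%. Compound 1 stands level with compound 2 and together they hold the lowest two of the three numbers; the step of no change at the digits printed from compound 1 to compound 2 (within the scatter) is no change at the digits printed, and the step of a number 3 percentage points higher from compound 1 to compound 3 (within the scatter) is within the scatter, as is a number 3 percentage points higher from compound 2 to compound 3 (within the scatter). The three measured compounds are thus indistinguishable in this assay.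

Compound 4 `COc1ccc(S(=O)(=O)c2cnc3ccc(OC)cc3c2N2CCC(C)CC2)cc1` keeps the methoxy of compound 1 on the core and alters a different part: 4-methoxyphenyl in place of 3-cyanophenyl on a sulfonyl sulfur. Among the compounds with values here, none of the measured steps touches the group on the sulfonyl sulfur, so no step bears directly on this change, and the expectation rests only on the uniformly high inhibition seen across compounds 1, 2 and 3. Compound 4 is therefore estimated at 75% in this assay, within 40% to 95%, which means an expected step of a number 15 percentage points lower from compound 1 to compound 4 (beyond the scatter) from compound 1, with the wide range reflecting that the group on the sulfonyl sulfur has not been varied among the measured compounds.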

Compound 4, a percentage reported as inhibition, at one concentration (the size of the read-out at that concentration, not a potency): 41%
For compound 4 the middle estimate is 34 percentage points above the measured one; low and high end bracket the measured number.
By their numbers in this assay, from the lowest: compound 4; then compounds 1, 2 and 3 (each within the scatter of the next).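

The group on the sulfonyl sulfur matters in this assay, unlike the group on the aromatic carbon of the shared core, where compounds 1, 2 and 3 stayed within the scatter of one another. Replacing 3-cyanophenyl with 4-methoxyphenyl, an exchange of equal heavy-atom count, gives a number 49 percentage points lower from compound 1 to compound 4 (beyond the scatter), so this position responds strongly to a single change. No measurement at hand accounts for this drop.

Because the change swaps both the substituent and its place on the phenyl ring, the compounds shown cannot separate the loss of the nitrile from the arrival of the methoxy. As far as these compounds go, it remains open where an unsubstituted phenyl, a 4-cyanophenyl or a 3-methoxyphenyl on the sulfonyl sulfur would fall, and whether the chloro and fluoro relatives would respond to this exchange as the methoxy compound does.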